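The compounds below may be only part of what the source reports. "The series", "measured", "known", "first", "only" and "open" are said of these compounds alone.

Of the compounds shown here, two have been tested in an ADME assay on BHK-21 cells (Mesocricetus auratus) for cytotoxicity, with a stated time of 3 days; a lower number here means that less compound is tolerated, a higher number that more compound is tolerated. Compound 1 `O=C(CCSc1nnc(-c2ccncc2)s1)Nc1c(Cl)cccc1Cl` gives 10300 nM. Compound 2 `O=C(CCSc1nnc(-c2ccncc2)s1)Nc1ccccc1Cl` reaches only the limit of the test, reported as > 50000 nM, so no exact number is known for it. Among the measured compounds shown here, the one step between measured compounds, an at least 4.8-fold higher number from compound 1 to compound 2 (0.68 log units; beyond the scatter), follows a change of hydrogen in place of chloro on an aromatic carbon; its size is only known as a lower bound because of the limit of > 50000 nM in this assay, at which 1 of the 2 values shown sits. Compound 2 therefore stands at the well-tolerated end of what has been measured, with a limit rather than a number.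

The next compound, compound 3 `O=C(CCSc1nnc(-c2ccncc2)s1)NCc1ccc(Cl)cc1`, differs from compound 2 by 4-chlorobenzyl in place of 2-chlorophenyl on an amide-type nitrogen. For the measured compounds named here, no measured step shows this kind of change, and the only step available, from compound 1 to compound 2, is itself open-ended. With compound 2 already at the limit, the expectation is a step of about an at least 1.2-fold lower number from compound 2 to compound 3 (0.09 log units; that floor lies within the scatter), which in practice means no clear movement beyond the scatter. On this basis compound 3 is expected to give 40000 nM in this assay, with a likely range from 15000 nM to 120000 nM.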

Compound 3, half-maximal cytotoxic concentration: 21500 nM
Estimate against measurement, compound 3: 1.9-fold (0.27 log units) above; the measured number falls inside the stated range.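

In this assay, among the compounds shown here, the earlier compounds showed only that removing a chlorine from the phenyl ring can shift the number, whereas compound 3 shows that the group on the amide-type nitrogen matters even when one chlorine is kept: replacing 2-chlorophenyl with 4-chlorobenzyl gives an at least 2.3-fold lower number from compound 2 to compound 3 (0.36 log units; beyond the scatter). On these data alone, the true size of that step is unknown, since the value for compound 2 is a limit and not a number: the limit of > 50000 nM in this assay, at which 1 of the 3 values shown sits. Replacing 2,6-dichlorophenyl with the same 4-chlorobenzyl group gives a 2.1-fold higher number from compound 1 to compound 3 (0.32 log units; beyond the scatter), so compound 3 falls between the other two, less well tolerated than compound 2 but better tolerated than compound 1.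

The compounds shown leave open whether the drop from compound 2 comes from the extra carbon that links the ring to the nitrogen or from the new place of the chlorine, a question that a plain benzyl group or a 4-chlorophenyl group on the same nitrogen could help to settle. Also open, as far as these compounds go, is how this assay would respond to a different kind of group on that nitrogen, such as a longer chain ending in an amine or a carboxylic acid.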